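A Fluorinated Cyclopropane Replaces Isopropyl on the Carbonyl

The compounds below may be only part of what the source reports. "The series", "measured", "known", "first", "only" and "open" are said of these compounds alone.

Three amides on a shared core have been measured in an assay on SH-EP1 cells for displacement of a labelled ligand from Neuronal acetylcholine receptor; alpha4/beta2 (Homo sapiens), read by scintillation counting; on this read-out lower numbers stand for stronger inhibition and higher numbers for weaker inhibition. Compound 1 `CC(=O)N1CC2CC(C1)N2` gives 150 nM, compound 2 `CCCC(=O)N1CC2CC(C1)N2` gives 14 nM, and compound 3 `CC(C)C(=O)N1CC2CC(C1)N2` gives 130 nM. Compound 3 therefore stands second highest of the three; the two steps that lead to it are a 1.2-fold lower number from compound 1 to compound 3 (0.06 log units; within the scatter) and a 9.3-fold higher number from compound 2 to compound 3 (0.97 log units; beyond the scatter). Compound 4 `O=C([C@H]1C[C@H]1F)N1CC2CC(C1)N2` carries 2-fluorocyclopropyl in place of isopropyl on a carbonyl carbon. For the measured compounds named here, the steps that bear on this change are an 11-fold lower number from compound 1 to compound 2 (1.03 log units; beyond the scatter) and a 9.3-fold higher number from compound 2 to compound 3 (0.97 log units; beyond the scatter): a longer straight chain brought a large gain, whereas branching at the carbonyl carbon brought none. A small ring is neither, so only a modest step toward a lower number is expected, a 2.2-fold lower number from compound 3 to compound 4 (0.34 log units; beyond the scatter). Compound 4 is thus estimated at 60 nM, with a range from 12 nM to 300 nM.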

Compound 4, inhibition constant: 1.1 nM
Compound 4: middle estimate off by 55-fold (1.74 log units), on the high side, and the stated range ends above it.
By their numbers in this assay, from the lowest: compound 4; then compound 2; then compounds 3 and 1 (each within the scatter of the next).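

On the carbonyl carbon, 2-fluorocyclopropyl gives the lowest number of the series, with a 120-fold lower number from compound 3 to compound 4 (2.07 log units; beyond the scatter) and a 13-fold lower number from compound 2 to compound 4 (1.10 log units; beyond the scatter) and also a 140-fold lower number from compound 1 to compound 4 (2.13 log units; beyond the scatter) in the same assay. The earlier compounds shown here showed a gain only with propyl, so this position can also take a ring carrying fluorine and reach a much lower number. Nothing available here explains this gain. On these data alone, whether plain cyclopropyl, without the fluorine, would reach a similar number stays open. So does the effect of the opposite arrangement at the 2 defined stereocentres.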